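Shifting the Phenyl Substituent from Acetyl to Ethyl

The source may hold more compounds than are shown below. What is called first, only, known or untested is meant among the compounds shown, and "the series" means these compounds.

Compound 3 `CC(=O)c1ccccc1OC1CCN(c2ccc(-n3ccnc3)nn2)CC1` stands second highest of the three numbers measured in an assay on microsomes from liver for inhibition of acyl-CoA desaturase 1 (Rattus norvegicus) (on this read-out higher numbers stand for weaker inhibition and lower numbers for stronger inhibition), where compound 3 gives 34 nM. Its nearest neighbour is compound 1 `Brc1ccccc1OC1CCN(c2ccc(-n3ccnc3)nn2)CC1`, which in this assay gives 5 nM, so that the step of a 6.8-fold higher number from compound 1 to compound 3 (0.83 log units; beyond the scatter) is modest. Further off is compound 2 `N#Cc1ccccc1OC1CCN(c2ccc(-n3ccnc3)nn2)CC1`, which in this assay gives 236 nM, the step of a 6.9-fold lower number from compound 2 to compound 3 (0.84 log units; beyond the scatter) being of the same modest size in the other direction, while the step of a 47-fold higher number from compound 1 to compound 2 (1.67 log units; beyond the scatter) is large.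

Compound 4 `CCc1cccc(OC2CCN(c3ccc(-n4ccnc4)nn3)CC2)c1` is not yet measured. The change from compound 3 is 3-ethylphenyl in place of 2-acetylphenyl on an oxygen on a saturated carbon. Within the data shown here, both measured steps that touch compound 3 bear on this change, since each also swaps the group on the phenyl ring, and each was modest; no measured step moves the group to another place on the ring, so that part of the change has no precedent here. A modest step is therefore expected in this assay, and the direction is uncertain. Compound 4 is expected to give about 20 nM in this assay, between 4 nM and 100 nM, which is the expected step of a 1.7-fold lower number from compound 3 to compound 4 (0.23 log units; within the scatter).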

Compound 4, half-maximal inhibitory concentration: 38 nM
Compound 4: the middle estimate sits 1.9-fold (0.28 log units) below what was measured; the range from low to high includes it.
By their numbers in this assay, from the lowest: compound 1; then compounds 3 and 4 (each within the scatter of the next); then compound 2.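

In this assay, 3-ethylphenyl in place of 2-acetylphenyl on an oxygen on a saturated carbon gives a 1.1-fold higher number from compound 3 to compound 4 (0.05 log units; within the scatter), so two groups that differ in their substitution and in the carbonyl, with its one hydrogen-bond acceptor, cannot be told apart on this read-out. This exchange, unlike the earlier swaps on the ring, therefore has no step beyond the scatter, and compound 4 keeps the same standing as compound 3 relative to the two other compounds, with a 6.2-fold lower number from compound 2 to compound 4 (0.79 log units; beyond the scatter) and a 7.6-fold higher number from compound 1 to compound 4 (0.88 log units; beyond the scatter), leaving the 2-bromophenyl group of compound 1 with the lower number and the 2-cyanophenyl group of compound 2 with the higher one. Nothing available here accounts for why the 3-ethylphenyl and 2-acetylphenyl groups read alike.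

Because the group and its place on the ring change together in this step, their separate contributions remain unresolved, and 2-ethylphenyl and 3-acetylphenyl groups would be needed to pull them apart. Also open, on these data alone, is how 3-bromophenyl, or a phenyl ring carrying an amine or a carboxylic acid, would read in this assay on this same core.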